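Removing the Bromine: From Compound 2 to Compound 3

This account rests on a few compounds, and the source may have more. Where it says the series, first, only, none or still open, it means among the compounds named here.

compound 1 `CCCC1=C(OCC)C(CCC)(CCC)C(=O)/C(=C(O)\C=C\c2ccccc2)C1=O`: 12.5 uM
compound 2 `CCCC1=C(OC)C(CCC)(CCC)C(=O)/C(=C(O)\C=C\c2ccc(Br)cc2)C1=O`: 4.7 uM

Of the compounds shown here, two have been measured in a functional assay on PC-3 cells (Homo sapiens) for antiproliferative activity, read by sulforhodamine B assay, with a stated time of 3 days; on this read-out higher numbers stand for an effect only at larger amounts of compound and lower numbers for an effect already at smaller amounts. Compound 1 `CCCC1=C(OCC)C(CCC)(CCC)C(=O)/C(=C(O)\C=C\c2ccccc2)C1=O` gives 12.5 uM, and compound 2 `CCCC1=C(OC)C(CCC)(CCC)C(=O)/C(=C(O)\C=C\c2ccc(Br)cc2)C1=O` gives 4.7 uM. Compound 2 holds the lower of the two numbers; compound 1 stands at a number higher by a margin beyond the usual scatter. Compound 3 `CCCC1=C(OC)C(CCC)(CCC)C(=O)/C(=C(O)\C=C\c2ccccc2)C1=O` is not yet measured. It differs from compound 2 in one place: hydrogen in place of bromo on an aromatic carbon. Going by the values given here, no measured pair shows this change on its own, so the expected size of the step can only be judged from compound 1, which also carries the 2-phenylethenyl group and gives 12.5 uM. A modest rise in the number, near the edge of the scatter, is expected, as a 1.9-fold higher number from compound 2 to compound 3 (0.28 log units; within the scatter). Compound 3 is therefore estimated at 9 uM, with a range from 4 uM to 20 uM.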

Compound 3, concentration for half-maximal effect: 8.2 uM
For compound 3 the middle estimate is 1.1-fold (0.04 log units) above the measured one; low and high end bracket the measured number.
By their numbers in this assay, from the lowest: compounds 2, 3 and 1 (each within the scatter of the next, the first and the last beyond it).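

In this assay the exchange of hydrogen for bromo on the aromatic carbon, para to a large group, can now be read on its own (a 1.7-fold higher number from compound 2 to compound 3 (0.24 log units; within the scatter)), and it stays within the scatter. Going by these compounds alone, the second single change, hydrogen in place of methyl on the saturated chain carbon bound to an oxygen on an unsaturated carbon, also stays within the scatter (a 1.5-fold lower number from compound 1 to compound 3 (0.18 log units; within the scatter)), so neither change alone accounts for a margin beyond the scatter like the one printed between compound 1 and compound 2. Nothing measured here gives a reason for these results. The compounds shown leave open whether an amine or a carboxylic acid on that aromatic carbon would move the number beyond the scatter. They also leave open what a longer chain on that oxygen would do.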